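The compounds below may be only part of what the source reports. "The series", "measured", "known", "first", "only" and "open" are said of these compounds alone.

In an in vitro ADME assay on microsomes (Mus musculus) for metabolic stability (a higher number here means that the compound lasts longer, a lower number that the compound disappears faster), compound 1 `Cc1c2c(n3c1CCN(C(=O)[C@H](C)N)CC[C@H](C)Nc1cc-3ccc1C(N)=O)CC(C)(C)CC2=O` gives > 0.5 h, which is a limit of the assay and not a number. Compound 2 `Cc1c2c(n3c1CCN(C(=O)CN)C[C@@H](C)[C@H](C)Nc1cc-3ccc1C(N)=O)CC(C)(C)CC2=O` gives > 0.5 h, which is also a limit. It therefore stands with compound 1 at the only mark seen so far, (the limit of > 0.5 h in this assay, at which 2 of the 2 values shown sit). Compound 3 `Cc1c2c(n3c1CCN(C(=O)[C@@H](N)C(C)C)C[C@@H](C)[C@H](C)Nc1cc-3ccc1C(N)=O)CC(C)(C)CC2=O` carries isopropyl in place of hydrogen on a saturated chain carbon bound to an amine nitrogen and a carbonyl carbon, with isopropyl in place of hydrogen on a saturated chain carbon bound to an amine nitrogen and a carbonyl carbon. Within the data shown here, no measured step is available as a guide, so the expected change in this assay is a step that the limit leaves unreadable from compound 2 to compound 3, none beyond the scatter. For compound 3 the estimated half-life is 0.6 h, with an expected range of 0.25 h to 1.5 h.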

Compound 3, half-life: 0.133 h
Beside the measured number, compound 3's estimate is 4.5-fold (0.65 log units) above it; the whole stated range lies above it.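

The position is not neutral: in this assay, isopropyl in place of hydrogen on a saturated chain carbon bound to an amine nitrogen and a carbonyl carbon gives an at least 3.7-fold lower number from compound 2 to compound 3 (0.57 log units; beyond the scatter). Among these compounds, this is the first readable step, and it shows that this single change can shorten the half-life beyond the scatter. Its full size stays unknown, as compound 2 stands at a limit of the assay and not at a number: the limit of > 0.5 h in this assay, at which 2 of the 3 values shown sit.

The compounds shown leave open whether an ethyl or a hydroxymethyl group on this carbon would shorten the half-life too. They also leave open how far the step extends past the limit.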